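A few compounds are considered here, and "the series" means these few. Any claim that something is new, unique, unknown or untested is made for them only; others in the source may bear on it.

Measured compounds in a functional assay on NCI-H460 cells (Homo sapiens) for cytotoxicity, read by MTT assay, with a stated time of 72 h; on this read-out higher numbers stand for weaker inhibition and lower numbers for stronger inhibition:

Compound 1 `CC(C)(C)C1=CC(=O)C=C(NCc2ccccc2)C1=O`, compound 1 gives 14000 nM
Compound 2 `CCCCCCCCNC1=CC(=O)C=C(C[C@]2(C)[C@@H](C)CC[C@]3(C)C(C)=CCC[C@@H]23)C1=O`, compound 2 gives 38000 nM
Compound 3 `CC(C)(C)C1=CC(=O)C(NCc2ccccc2)=CC1=O`, compound 3 gives 19000 nM

Among the three measured compounds, compound 1 has the lowest number in this assay. Its nearest neighbour is compound 3, whose number is within the usual scatter of compound 1, so the two cannot be told apart with confidence. Compound 2 lies furthest away, beyond the scatter, at a higher number than compound 1. All three are weak inhibitors on this read-out.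

Compound 4 `CCCCCCCCNC1=CC(=O)C=C(C(C)(C)C)C1=O` has not yet been measured. Relative to compound 1 the change is heptyl in place of phenyl on a saturated chain carbon bound to an amine nitrogen. Going by the values given here, compound 2 carries the same chain on its nitrogen but a different group elsewhere on the shared core, so no measured pair isolates this change. Given that compound 1 gives 14000 nM and compound 2 gives 38000 nM, a small step toward a higher number, or none beyond the scatter, is expected in this assay.

For compound 4 the expected step from compound 1 is a 1.4-fold higher number from compound 1 to compound 4 (0.15 log units; within the scatter). Compound 4 is therefore estimated at 20000 nM, within a range from 7000 nM to 60000 nM.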

Compound 4, half-maximal inhibitory concentration: 20000 nM
Compound 4: the middle estimate sits on the measured number at the digits printed, and the stated range covers the measured number.
By their numbers in this assay, from the lowest: compounds 1, 3, 4 and 2 (each within the scatter of the next, the first and the last beyond it).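

In this assay the swap of heptyl for phenyl on a saturated chain carbon bound to an amine nitrogen gives a 1.4-fold higher number from compound 1 to compound 4 (0.15 log units; within the scatter) and so cannot be told apart from no change at all. This pair differs in one place only, and it shows that at this place an open chain can stand in for the aromatic ring with no measurable difference in this cytotoxicity read-out. Nothing available explains why the two groups give such similar numbers.

From the compounds shown here alone, it remains open whether a much shorter chain such as ethyl, or a chain ending in an amine or a carboxylic acid, would shift the number beyond the scatter. Going by these compounds, a phenyl carrying a fluorine or a methoxy group at this place is an equally open case.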